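Benzyloxy in place of trifluoromethyl on the aryl ring

This account rests on a few compounds, and the source may have more. Where it says the series, first, only, none or still open, it means among the compounds named here.

In a functional assay on WM 266-4 cells (Homo sapiens) for antiproliferative activity, read by MTT assay, with a stated time of 48 h (on this read-out higher numbers stand for weaker inhibition of growth and lower numbers for stronger inhibition of growth), compound 3 `FC(F)(F)c1ccc(C2=NN(C(=S)Nc3ccccc3)C(c3ccc4c(c3)OCCO4)C2)cc1` gives 52400 nM, the highest number of the three measured. Compound 1 `S=C(Nc1ccccc1)N1N=C(c2ccccc2)CC1c1ccc2c(c1)OCCO2` gives 3180 nM and compound 2 `Cc1ccc(C2=NN(C(=S)Nc3ccccc3)C(c3ccc4c(c3)OCCO4)C2)cc1` gives 10300 nM. The steps of a 16-fold higher number from compound 1 to compound 3 (1.22 log units; beyond the scatter) and a 5.1-fold higher number from compound 2 to compound 3 (0.71 log units; beyond the scatter) both arrive at trifluoromethyl on this aromatic carbon, while a 3.2-fold higher number from compound 1 to compound 2 (0.51 log units; beyond the scatter) is the smaller change. Compound 4 `S=C(Nc1ccccc1)N1N=C(c2ccc(OCc3ccccc3)cc2)CC1c1ccc2c(c1)OCCO2` carries benzyloxy in place of trifluoromethyl on an aromatic carbon. Among the measured compounds shown here, no measured step introduces benzyloxy, so the only guide is that every step away from trifluoromethyl on this carbon gave a lower number in this assay. A lower number is therefore expected for compound 4, with a 6.6-fold lower number from compound 3 to compound 4 (0.82 log units; beyond the scatter) as the estimated step. The estimate for compound 4 is 8000 nM, with a range from 2500 nM to 30000 nM.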

Compound 4, concentration for 50% growth inhibition: 420 nM
Compound 4: the middle estimate sits 19-fold (1.28 log units) above what was measured, and the stated range ends above it.
By their numbers in this assay, from the lowest: compound 4; then compound 1; then compound 2; then compound 3.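

In this assay, among the compounds shown here, this aromatic carbon tolerates a much larger group than the earlier compounds showed: benzyloxy gives the lowest number of the four, with steps of a 120-fold lower number from compound 3 to compound 4 (2.10 log units; beyond the scatter) and a 25-fold lower number from compound 2 to compound 4 (1.39 log units; beyond the scatter) and a 7.6-fold lower number from compound 1 to compound 4 (0.88 log units; beyond the scatter) as the three comparisons. Hydrogen no longer gives the lowest number, so compound 4 goes against the earlier trend of higher numbers with methyl and trifluoromethyl in place of hydrogen. Nothing available explains this reversal.

As far as these compounds go, it remains open whether the oxygen or the added aromatic ring accounts for the lower number. Methoxy, phenyl and an amine on this carbon would help separate these possibilities.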